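Formyl replaced by a silicon-bearing group on compound 2

This account rests on a few compounds, and the source may have more. Where it says the series, first, only, none or still open, it means among the compounds named here.

Three compounds share one core and differ only in the aryl group on the amine nitrogen. Compound 1 `C=C1[C@@H](OC(C)=O)C[C@@H]2[C@](C)(COC=O)[C@H](OC(C)=O)CC[C@@]2(C)[C@@H]1C[C@@H](Nc1ccccc1C(=O)O)C1=CCOC1=O` gives 45900 nM in a functional assay on A549 cells (Homo sapiens) for cytotoxicity, read by sulforhodamine B assay; on this read-out higher numbers stand for weaker inhibition and lower numbers for stronger inhibition. Compound 2 `C=C1[C@@H](OC(C)=O)C[C@@H]2[C@](C)(COC=O)[C@H](OC(C)=O)CC[C@@]2(C)[C@@H]1C[C@@H](Nc1ccc(O)cc1)C1=CCOC1=O` gives 29100 nM in this assay, and compound 3 `C=C1[C@@H](OC(C)=O)C[C@@H]2[C@](C)(COC=O)[C@H](OC(C)=O)CC[C@@]2(C)[C@@H]1C[C@@H](Nc1ccc(F)cc1)C1=CCOC1=O` gives 21300 nM. Compound 2 holds the second highest of the three numbers; its nearest neighbour is compound 3, with a 1.4-fold lower number from compound 2 to compound 3 (0.14 log units; within the scatter), and its furthest is compound 1, with a 1.6-fold lower number from compound 1 to compound 2 (0.20 log units; within the scatter), both within the scatter. Within the data shown here, the only step beyond the scatter is a 2.2-fold lower number from compound 1 to compound 3 (0.33 log units; beyond the scatter), a modest one.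

Compound 4 `C=C1[C@@H](OC(C)=O)C[C@@H]2[C@](C)(CO[Si](C)(C)C(C)(C)C)[C@H](OC(C)=O)CC[C@@]2(C)[C@@H]1C[C@@H](Nc1ccc(O)cc1)C1=CCOC1=O` departs from compound 2 at a different place on the core: a group of 7 heavy atoms (6 carbon, 1 silicon; no ring) in place of a group of 2 heavy atoms (1 carbon, 1 oxygen; no ring), on an oxygen on a saturated carbon. None of the three measured steps alters the oxygen on a saturated carbon; all three vary the aryl group on the amine nitrogen, and all three are small. Among the measured compounds shown here, no measured step therefore bears directly on the change from compound 2 to compound 4, and the expectation rests on the flatness of the series alone. The step of a 1.0-fold lower number from compound 2 to compound 4 (0.00 log units; within the scatter) is expected to stay within the scatter, with a wide allowance for the untested position. Compound 4 is estimated at 29000 nM, within a range of 10000 nM to 85000 nM.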

Compound 4, half-maximal inhibitory concentration: 5090 nM
Compound 4: middle estimate off by 5.7-fold (0.76 log units), on the high side; measured number outside the range, below it.
By their numbers in this assay, from the lowest: compound 4; then compounds 3, 2 and 1 (each within the scatter of the next, the first and the last beyond it).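

The oxygen on a saturated carbon is a place on the shared core where the number in this assay moves: with the formyl replaced by the group of 7 heavy atoms (6 carbon, 1 silicon), the result is a 5.7-fold lower number from compound 2 to compound 4 (0.76 log units; beyond the scatter), a larger step than the widest one among the aryl groups on the amine nitrogen, a 2.2-fold lower number from compound 1 to compound 3 (0.33 log units; beyond the scatter). The formyl is therefore not needed to keep this read-out, at least with the 4-hydroxyphenyl on the amine nitrogen. Nothing available explains the step.

On these data alone, whether a free hydroxy, an acetyl or a benzyl on this oxygen would give a similar number remains open, so the silicon cannot be separated from the rest of the group. Also open, as far as these compounds go, is whether the same change gives a step of similar size with the 4-fluorophenyl of compound 3.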